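Carboxy-to-ketone switch on the piperidine of compound 3

A few compounds are considered here, and "the series" means these few. Any claim that something is new, unique, unknown or untested is made for them only; others in the source may bear on it.

Compound 3 `O=C(O)C1CCN(C2CN(CCC3(c4ccc(Cl)c(Cl)c4)CCC(=O)N(CC4CC4)C3)C2)CC1` gives 0.398 nM in an assay on isolated protein (artery, Oryctolagus cuniculus) with Substance-P receptor (Homo sapiens) as the target (on this read-out higher numbers stand for weaker binding and lower numbers for tighter binding), and carries the lowest number of the three measured compounds. Compound 1 `CS(=O)(=O)N1CCN(C2CN(CCC3(c4ccc(Cl)c(Cl)c4)CCC(=O)N(CC4CC4)C3)C2)CC1` gives 3.16 nM in this assay and compound 2 `NC(=O)N1CCN(C2CN(CCC3(c4ccc(Cl)c(Cl)c4)CCC(=O)N(CC4CC4)C3)C2)CC1` gives 5.01 nM; the two differ only a 1.6-fold higher number from compound 1 to compound 2 (0.20 log units; within the scatter). Against those two, compound 3 separates clearly: a 7.9-fold lower number from compound 1 to compound 3 (0.90 log units; beyond the scatter) and a 13-fold lower number from compound 2 to compound 3 (1.10 log units; beyond the scatter). In both steps the 4-carboxypiperidin-1-yl group is the one that comes with the lower number.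

Compound 4 `O=C1CCN(C2CN(CCC3(c4ccc(Cl)c(Cl)c4)CCC(=O)N(CC4CC4)C3)C2)CC1` has not been measured. It differs from compound 3 (4-oxopiperidin-1-yl in place of 4-carboxypiperidin-1-yl on a saturated ring carbon). Among the measured compounds shown here, no measured step removes the carboxylic acid in this way, so the bearing is indirect: compounds 1 and 2 show that without the acid the numbers sit higher, and compound 4 likewise loses the hydrogen-bond donor counted above. The expectation is therefore a move back toward the numbers of compounds 1 and 2, estimated as a 7.5-fold higher number from compound 3 to compound 4 (0.88 log units; beyond the scatter) in this assay. Compound 4 is expected at 3 nM, within 1 nM to 10 nM.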

Compound 4, dissociation constant: 1.26 nM
The estimate for compound 4 lay 2.4-fold (0.38 log units) above the measured number; low and high end bracket the measured number.
By their numbers in this assay, from the lowest: compound 3; then compound 4; then compounds 1 and 2 (each within the scatter of the next).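

Replacing the acid group with the ketone group on the saturated ring carbon gives in this assay a 3.2-fold higher number from compound 3 to compound 4 (0.50 log units; beyond the scatter) and so keeps part of the low number seen at this position. The 4-oxopiperidin-1-yl group also stands clear of both piperazine groups, with a 2.5-fold lower number from compound 1 to compound 4 (0.40 log units; beyond the scatter) and a 4.0-fold lower number from compound 2 to compound 4 (0.60 log units; beyond the scatter) as the steps, so a number below those of the 4-(methylsulfonyl)piperazin-1-yl and 4-carbamoylpiperazin-1-yl groups does not depend on the carboxylic acid alone. No measurement at hand gives a cause for this order of the groups.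

Still open, on these data alone, is where a 4-hydroxypiperidin-1-yl group, a 4-aminopiperidin-1-yl group or a longer chain ending in a carboxylic acid would fall relative to compound 3 and compound 4. The shown compounds also leave open whether this order of groups holds when the cyclopropylmethyl group of the shared core is replaced.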